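This account rests on a few compounds, and the source may have more. Where it says the series, first, only, none or still open, it means among the compounds named here.

Compound 1 `COc1cc(C)c(S(=O)(=O)N(C)CCOCC(=O)N2CCN(C3CCN(C4CC4)CC3)CC2)c(C)c1` gives 0.8 nM in an assay on HEK293 cells for displacement of a labelled ligand from B1 bradykinin receptor (Homo sapiens), read by scintillation counting; a lower number here means a stronger inhibitor, a higher number a weaker inhibitor.
Compound 2 `CN(Cc1ccc(C2=NCCN2)cc1)C(=O)COCCN(C)S(=O)(=O)c1ccc(OC(F)(F)F)cc1` gives 85 nM in this assay.
Compound 3 `COc1cc(C)c(S(=O)(=O)N(C)CCOCC(=O)N2CCC(CN3CCN(C)CC3)CC2)c(C)c1` gives 4.7 nM in this assay.

Among these three, compound 1 stands at the lowest number. Its nearest neighbour is compound 3, whose higher number lies beyond the usual scatter, and compound 2 sits furthest away, higher still. Among the measured compounds shown here, no pair of measured compounds differs in one place only, so no step of known size is available as a guide.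

Compound 4 `CCN1CCC(N2CCN(C(=O)COCCN(C)S(=O)(=O)c3c(C)cc(OC)cc3C)CC2)CC1` is the next compound to be measured in this assay. It differs from compound 1 in a single spot: ethyl in place of cyclopropyl on an amine nitrogen in a ring. Because compound 1 gives 0.8 nM and the change is confined to the group on that ring nitrogen, a small step is expected, more likely upward than downward, and probably not clearly beyond the scatter. Compound 4 is therefore estimated to give about 1.3 nM, with a range from 0.5 nM to 3.5 nM. This expected estimate corresponds to a step of a 1.6-fold higher number from compound 1 to compound 4 (0.21 log units; within the scatter) in this assay.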

Compound 4, inhibition constant: 0.2 nM
Estimate against measurement, compound 4: 6.5-fold (0.81 log units) above; the whole stated range lies above it.
By their numbers in this assay, from the lowest: compound 4; then compound 1; then compound 3; then compound 2.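

In this assay the change on the amine nitrogen in the six-membered ring gives a 4.0-fold lower number from compound 1 to compound 4 (0.60 log units; beyond the scatter) and supplies the first step of known size among these compounds. It shows that the number responds to the group at this position, even when that group is small, and that the three-membered ring of carbon in cyclopropyl is not required for a low number, as the open-chain ethyl gives the lower value. Nothing measured here accounts for the difference between the two groups.

The compounds shown leave open whether methyl, isopropyl or a longer chain such as n-propyl on that nitrogen would lower the number further or raise it again. They also leave open whether the same change would give a step of similar size on a different core.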